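Extending the amide chain on a methoxyphenyl analogue

The source may hold more compounds than are shown below. What is called first, only, known or untested is meant among the compounds shown, and "the series" means these compounds.

Compound 1, `CNC(=O)c1cc(Oc2ccc(NC(=O)c3cc4cccnc4n(-c4ccc(F)cc4)c3=O)cc2)ccn1`: 2910 nM
Compound 2, `CNC(=O)c1cc(Oc2ccc(NC(=O)c3cc4cccnc4n(-c4ccc(OC)cc4)c3=O)cc2)ccn1`: "not determined" (no result reported)

Both compounds were tested in a functional assay on U-87MG ATCC cells for antiproliferative activity against U-87 MG (Homo sapiens), read by MTT assay, with a stated time of 72 h; on this read-out lower numbers stand for stronger inhibition and higher numbers for weaker inhibition. Compound 1 gives 2910 nM in this assay. Compound 2 is recorded as "not determined" (no result reported) in this assay; it has no single number, so it stands nowhere on the scale, and nothing can be read from its pairing with compound 1.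

Compound 3, `CCCNC(=O)c1cc(Oc2ccc(NC(=O)c3cc4cccnc4n(-c4ccc(OC)cc4)c3=O)cc2)ccn1`, differs from compound 2 by ethyl in place of hydrogen on a saturated chain carbon bound to an amide-type nitrogen. Going by the values given here, no step between measured compounds exists for this change, and the only number in the set belongs to compound 1, with compound 3 sharing the core but not the same substituent pattern. With nothing in the data to point either way, the step from compound 2 to compound 3 is expected to be of no size beyond the usual scatter, neither clearly towards stronger nor weaker inhibition, and the anchor for any number is compound 1 with 2910 nM. On that basis compound 3 is estimated at 3000 nM in this assay, with a wide range from 700 nM to 13000 nM.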

Compound 3, half-maximal inhibitory concentration: 8210 nM
Beside the measured number, compound 3's estimate is 2.7-fold (0.44 log units) below it, and the stated range covers the measured number.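

No new step can be read from this result: compound 2 has no number in this assay, and compound 3 differs from compound 1 in more than one place. Nothing else in the data bears on the result for compound 3. The compounds shown leave open what the change from methylcarbamoyl to propylcarbamoyl does to inhibition.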